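Carbamoyl in Place of Methyl on a Weak Trypsin Binder

The source may report more compounds than this note shows. Statements on the series, on what has been measured and on what is new or still open speak of the compounds shown alone.

The compounds here share one core and were tested in an assay on isolated protein for inhibition of Trypsin (Homo sapiens); on this read-out higher numbers stand for weaker inhibition and lower numbers for stronger inhibition. Compound 1 `Cc1nn(-c2cccc(CN)c2)c2c(F)c(-c3ccc(N4CCCC4=O)cc3)ccc12` gives 702 nM in this assay. Compound 2 `Cc1nn(-c2cccc(CN)c2)c2cc(-c3ccc(N4CCCC4=O)cc3)ccc12` carries a hydrogen where compound 1 carries a fluoro. In this assay compound 2 gives > 10000 nM, which is a limit of the assay rather than a number. That single change brought an at least 14-fold higher number from compound 1 to compound 2 (1.15 log units; beyond the scatter). Compound 3 `Cc1nn(-c2ccc3onc(N)c3c2)c2c(F)c(-c3ccc(N4CCCCC4=O)cc3F)ccc12` is the starting point of the step followed here. In this assay compound 3 gives > 10000 nM, a limit of the assay and not a number; among the values shown it sits at the limit of > 10000 nM in this assay, at which 2 of the 3 values shown sit.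

Compound 4 `NC(=O)c1nn(-c2ccc3onc(N)c3c2)c2c(F)c(-c3ccc(N4CCCCC4=O)cc3F)ccc12` differs from compound 3 in one place: carbamoyl in place of methyl on an aromatic carbon. No measured step among these compounds concerns this change; the only measured step, an at least 14-fold higher number from compound 1 to compound 2 (1.15 log units; beyond the scatter), describes a different change and so does not bear on it. With compound 3 sitting at the limit, no shift beyond the scatter in either direction can be read from these numbers, and the expected step is a number no higher from compound 3 to compound 4 (the limit leaves the size open). Compound 4 is therefore estimated to give about 10000 nM in this assay, within a range from 3000 nM to 30000 nM, most likely reported again as a limit.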

Compound 4, inhibition constant: > 10000 nM
Compound 4: a limit, no number; the forecaster's own chance of this, stated with the estimate: 70%; the middle value sits exactly at the limit.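

For the compounds shown here, compound 3 and compound 4 each give a limit rather than a number in this assay, so no step between them can be read. The compounds shown leave open whether carbamoyl in place of methyl on an aromatic carbon shifts inhibition in either direction, with both compounds resting at the same limit: the limit of > 10000 nM in this assay, at which 3 of the 4 values shown sit.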